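Swapping Cyclopentyloxy for Hydroxypiperidine on a Shared Core

The source may report more compounds than this note shows. Statements on the series, on what has been measured and on what is new or still open speak of the compounds shown alone.

Of the compounds shown here, two have been measured in a functional assay for inhibition of sodium/hydrogen exchanger (Oryctolagus cuniculus); on this read-out lower numbers stand for stronger inhibition and higher numbers for weaker inhibition. Compound 1 `Cc1cc(-c2ccc(Cl)cc2)c(S(C)(=O)=O)cc1C(=O)N=C(N)N` gives 45 nM. Compound 2 `Cc1cc(OC2CCCC2)c(S(C)(=O)=O)cc1C(=O)N=C(N)N` gives 27 nM. Within the data shown here, the single measured step, a 1.7-fold lower number from compound 1 to compound 2 (0.22 log units; within the scatter), lies within the scatter, so compound 2 holds the lowest of the two numbers without standing apart from compound 1. Compound 3 `Cc1cc(N2CCCC(O)C2)c(S(C)(=O)=O)cc1C(=O)N=C(N)N` has not been measured; it differs from compound 2 in one place: 3-hydroxypiperidin-1-yl in place of cyclopentyloxy on an aromatic carbon. Among the measured compounds shown here, no measured step tests a group like the one that enters, so the only guidance is that replacing the group at this position by a quite different one, as between compound 1 and compound 2, changed the number little. On that basis the expected change is a 1.1-fold higher number from compound 2 to compound 3 (0.05 log units; within the scatter), within the scatter, though with wide uncertainty. Compound 3 is estimated at 30 nM, with a range from 10 nM to 90 nM.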

Compound 3, half-maximal inhibitory concentration: 30 nM
Compound 3: middle estimate and measured number agree at the digits printed, and the stated range covers the measured number.
By their numbers in this assay, from the lowest: compounds 2, 3 and 1 (each within the scatter of the next).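

In this assay, the step from the cyclopentyloxy compound is a 1.1-fold higher number from compound 2 to compound 3 (0.05 log units; within the scatter). On this aromatic carbon, ortho to a methylsulfonyl group, the number therefore does not separate 3-hydroxypiperidin-1-yl, which has a hydrogen-bond donor, from cyclopentyloxy, which has none. The comparison with 4-chlorophenyl, a 1.5-fold lower number from compound 1 to compound 3 (0.18 log units; within the scatter), gives the same reading, so three quite different groups, attached through carbon, oxygen and nitrogen, now give numbers within the scatter of one another, and nothing available explains why they sit so close.

Piperidin-1-yl without the hydroxyl would show whether that hydroxyl matters at all here. Going by these compounds, it also remains open whether this position accepts any group, since a carboxylic acid, a primary amine or a small methoxy could still move the number well beyond the scatter.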